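The compounds below may be only part of what the source reports. "The series", "measured", "known", "first", "only" and "open" are said of these compounds alone.

In a functional assay on CHO cells for agonist activity at Melanocyte-stimulating hormone receptor (Homo sapiens), read by a luciferase reporter, with a stated time of 4 h (on this read-out higher numbers stand for an effect only at larger amounts of compound and lower numbers for an effect already at smaller amounts), the series begins with compound 1, whose structure is `CC(C)N(C(=O)CN1C=CN(c2ccccc2)C(=O)[C@H](Cc2n[nH]c3ccccc23)C1=O)c1ccccc1` and which gives 295 nM. Compound 3, with the structure `CC(C)N(C(=O)CN1C=CN(c2ccccc2)C(=O)[C@H](Cc2n[nH]c3cc(F)ccc23)C1=O)c1ccccc1`, differs from it by a single fluoro on the aromatic carbon; in this assay compound 3 gives 35.5 nM. The change in the other direction is hydrogen in place of fluoro on an aromatic carbon and it produced an 8.3-fold higher number from compound 3 to compound 1 (0.92 log units; beyond the scatter).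

Compound 2, with the structure `O=C1C(Cc2n[nH]c3cc(F)ccc23)C(=O)N(c2ccccc2)C=CN1CC(=O)N1CCCCc2ccccc21`, carries the same fluoro but a different core; the difference between the two cores is not broken down here. In this assay compound 2 gives 1.59 nM, the lowest of the three numbers, and its distance from compound 3 and from compound 1 lies beyond the scatter in both cases.

Compound 4, whose structure is `O=C1C(Cc2n[nH]c3ccccc23)C(=O)N(c2ccccc2)C=CN1CC(=O)N1CCCCc2ccccc21`, has not yet been measured in this assay. It stands to compound 2 as compound 1 stands to compound 3: the change is hydrogen in place of fluoro on an aromatic carbon, the same change at the same place, and it occurs twice among the compounds shown. Among the measured compounds shown here, on the evidence of compound 3 and compound 1 alone, with an 8.3-fold higher number from compound 3 to compound 1 (0.92 log units; beyond the scatter) as the one measured step of this kind, compound 4 is expected to follow the same direction, so the step from compound 2 to compound 4 is estimated as an 8.2-fold higher number from compound 2 to compound 4 (0.91 log units; beyond the scatter). Compound 4 is therefore expected to give about 13 nM in this assay, with a range from 4 nM to 45 nM.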

Compound 4, half-maximal effective concentration: 1.59 nM
Compound 4: the middle estimate sits 8.2-fold (0.91 log units) above what was measured; the whole stated range lies above it.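

In this assay, hydrogen in place of fluoro on an aromatic carbon did not behave alike on the two cores, for the new step reads no change at the digits printed from compound 2 to compound 4 (within the scatter), and the two steps compare as follows: the same change on two cores in this assay, an 8.3-fold higher number (0.92 log units; beyond the scatter) from compound 3 to compound 1 and no change at the digits printed (within the scatter) from compound 2 to compound 4, 8.3-fold (0.92 log units) apart, beyond the scatter of two such steps Among these four compounds, then, the step measured on one core gave no reliable guide to the step on the other, and the fluoro mattered on the core shared by compound 1 and compound 3 but left no readable trace on the core shared by compound 2 and compound 4. Among the compounds shown here, this does not show why the two steps part, nor which feature of the cores is responsible, since the difference between the cores is not broken down and each core offers only a single pair.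

Going by these compounds, it remains open whether chloro, methyl or methoxy on that same aromatic carbon would follow the pattern of compound 3 and compound 1 or that of compound 2 and compound 4. On these data alone, it also remains open how the same exchange of fluoro for hydrogen would read on a third core, or with the fluoro placed on another carbon of the same six-membered aromatic ring.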